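Carbamate nitrogen variation in a weakly antiproliferative fused-acetal series

The source may report more compounds than this note shows. Statements on the series, on what has been measured and on what is new or still open speak of the compounds shown alone.

Three members of the series have been measured in a functional assay on cells (Endothelial cell, Sus scrofa) for antiproliferative activity; on this read-out lower numbers stand for stronger inhibition and higher numbers for weaker inhibition. Compound 1 `CO[C@@H]1C(=O)CO[C@]2(COC(C)(C)O2)[C@@]1(O)C1(C)CO1` gives 119000 nM in this assay. Compound 2 `CNC(=O)O[C@@H]1CO[C@]2(COC(C)(C)O2)[C@@](O)(C2(C)CO2)[C@@H]1OC` gives 195000 nM in this assay. Compound 3 `CCOC(=O)CNC(=O)O[C@@H]1CO[C@]2(COC(C)(C)O2)[C@@](O)(C2OC2CC(C)C)[C@@H]1OC` gives 343000 nM in this assay. Compound 2 thus holds the second highest of the three numbers; its nearest neighbour is compound 1, whose number is lower by a margin within the scatter, and the furthest is compound 3, whose number is higher by a margin that is also within the scatter. Going by the values given here, on these numbers no member of the trio can be set apart from the others, and all three sit at the weak end of this assay.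

Compound 4 `CO[C@@H]1[C@H](OC(=O)NC(=O)CCl)CO[C@]2(COC(C)(C)O2)[C@@]1(O)C1(C)CO1` has not yet been measured. It differs from compound 2 in one place: (chloromethyl)carbonyl in place of methyl on an amide-type nitrogen. Among the compounds with values here, no pair of measured compounds differing in a single place exists here, so there is no measured step to lean on. The step is expected to be small, with no direction beyond the scatter implied, given that the three measured numbers span a range within the scatter of one another. Compound 4 is estimated at 170000 nM, with a range from 60000 nM to 450000 nM. The expected step of a 1.1-fold lower number from compound 2 to compound 4 (0.06 log units; within the scatter) therefore lies inside the usual scatter.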

Compound 4, half-maximal inhibitory concentration: 57000 nM
The estimate for compound 4 lay 3.0-fold (0.47 log units) above the measured number; measured number outside the range, below it.
By their numbers in this assay, from the lowest: compound 4; then compounds 1, 2 and 3 (each within the scatter of the next, the first and the last beyond it).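

In this assay, the amide-type nitrogen of the carbamate is a place where a single change can move the number: a 3.4-fold lower number from compound 2 to compound 4 (0.53 log units; beyond the scatter), a modest step but one beyond the scatter, with (chloromethyl)carbonyl in place of methyl. Going by these compounds alone, the three earlier compounds could not show this, since they offered no single-place pair and their numbers stayed within the scatter of their nearest neighbours. The larger group, with 4 heavy atoms against 1 and a hydrogen-bond acceptor that methyl lacks, is accommodated here with a lower number rather than a higher one, though this rests on one pair and no measurement available here bears on the reason for the step.

From the compounds shown here alone, whether the step belongs to the carbonyl or to the chlorine stays open; an acetyl group on the same amide-type nitrogen would separate the two, and a 3-chloropropanoyl group would test the length of the chain. Also open, going by these compounds, is whether (chloromethyl)carbonyl gives a step of similar size on the core of compound 3, where the nitrogen carries a different group.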